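Swapping the Aryl Group on Compound 1

This account rests on a few compounds, and the source may have more. Where it says the series, first, only, none or still open, it means among the compounds named here.

Measured so far in a physicochemical assay for permeability, using PAMPA; on this read-out higher numbers stand for higher permeability and lower numbers for lower permeability:
compound 1 `Cc1oc(-c2c(F)cccc2F)nc1CN1CCC(C(=O)NCCCN2C[C@H](C)C[C@H](C)C2)CC1`: 82.4 10^-6 cm/s
compound 2 `CC[C@@H]1C[C@H](CC)CN(CCCNC(=O)C2CCN(Cc3nc(-c4c(F)cccc4F)oc3C)CC2)C1`: 130 10^-6 cm/s
compound 3 `Cc1ccccc1-c1nc(CN2CCC(C(=O)N3CCN(CCN(C)C)CC3)CC2)c(C)o1`: 14 10^-6 cm/s

Compound 1 gives the second highest of the three numbers in this assay. Its nearest neighbour is compound 2, reached by the change a 1.6-fold higher number from compound 1 to compound 2 (0.20 log units; within the scatter). Compound 3 stands far lower, but it differs from compound 1 in more than one place, so its value only shows where a different aryl group together with a different amide end can land.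

Compound 4 `COc1ccc(-c2nc(CN3CCC(C(=O)NCCCN4C[C@H](C)C[C@H](C)C4)CC3)c(C)o2)cc1OC` differs from compound 1 in one place: 3,4-dimethoxyphenyl in place of 2,6-difluorophenyl on an aromatic carbon. Among the measured compounds shown here, no measured step touches this position; the only measured step concerns the 3,5-dimethylpiperidin-1-yl end and stays within the scatter. The new group brings two hydrogen-bond acceptors where the old one had none, which in this assay often goes with a lower number. Compound 4 is therefore expected to give 45 10^-6 cm/s, estimated between 20 10^-6 cm/s and 110 10^-6 cm/s. The expected step is a 1.8-fold lower number from compound 1 to compound 4 (0.26 log units; within the scatter).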

Compound 4, apparent permeability: 81.9 10^-6 cm/s
Estimate against measurement, compound 4: 1.8-fold (0.26 log units) below, within the range that was stated.
By their numbers in this assay, from the lowest: compound 3; then compounds 4, 1 and 2 (each within the scatter of the next).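

In this assay, among the compounds shown here, replacing 2,6-difluorophenyl with 3,4-dimethoxyphenyl on this aromatic carbon gives a 1.0-fold lower number from compound 1 to compound 4 (0.00 log units; within the scatter), the first measured step at this position. The entering group carries 2 hydrogen-bond acceptors and the leaving group carries none, yet the two compounds cannot be told apart on this read-out, so for this pair, acceptors added at this position do not go with a lower number. No measurement shown here explains this result.

As far as these compounds go, it remains open whether a phenyl ring bearing a carboxylic acid or an amine would also stay within the scatter at this position. From the compounds shown here alone, it is equally open whether 3,4-dimethoxyphenyl would read the same way alongside the 3,5-diethylpiperidin-1-yl end of compound 2.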